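Thiazolylethoxy Replacing Fluorophenylethylsulfanyl: Microsomal Half-Life

This account rests on a few compounds, and the source may have more. Where it says the series, first, only, none or still open, it means among the compounds named here.

Going by the values given here, compound 3 `Cc1nc(C)c([C@H](OC(C)(C)C)C(=O)O)c(N2CCC(C)(C)CC2)c1-c1ccc(SCCc2ccc(F)cc2)cc1` is one of three compounds measured in an ADME assay on microsomes from liver (Rattus norvegicus) for metabolic stability, read by LC-MS, tested at 0.5 uM; on this read-out lower numbers stand for a shorter-lived compound and higher numbers for a longer-lived compound. In this assay compound 3 gives > 2 h, which is a limit of the assay and not a number. Compound 1 `Cc1nc(C)c([C@H](OC(C)(C)C)C(=O)O)c(N2CCC(C)(C)CC2)c1-c1ccc(OCCc2cc(F)c(F)cc2F)cc1` also gives a limit in this assay, > 2 h. Compound 2 `Cc1nc(C)c([C@H](OC(C)(C)C)C(=O)O)c(N2CCC(C)(C)CC2)c1-c1ccc(CCCc2ccc(F)cc2)cc1` likewise gives the limit > 2 h in this assay. The steps a step that the two limits leave unreadable from compound 1 to compound 2, a step that the two limits leave unreadable from compound 1 to compound 3 and a step that the two limits leave unreadable from compound 2 to compound 3 therefore cannot be sized, as the limit of > 2 h in this assay, at which 3 of the 3 values shown sit, shows. Compound 4 `Cc1nc(CCOc2ccc(-c3c(C)nc(C)c([C@H](OC(C)(C)C)C(=O)O)c3N3CCC(C)(C)CC3)cc2)cs1` differs from compound 3 by 2-(2-methyl-1,3-thiazol-4-yl)ethoxy in place of (2-(4-fluorophenyl)ethyl)sulfanyl on an aromatic carbon. Among the compounds with values here, no measured step covers this change, so no direction can be read from the data; every measured value sits at the limit. Compound 4 is expected to give 2 h in this assay, between 0.8 h and 4 h, an expected step of a number no higher from compound 3 to compound 4 (the limit leaves the size open).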

Compound 4, half-life: 1.75 h
For compound 4 the middle estimate is 1.1-fold (0.06 log units) above the measured one, within the range that was stated.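

Going by these compounds alone, at this place, para to a large group, 2-(2-methyl-1,3-thiazol-4-yl)ethoxy gives the first reading in this assay that is a number and not a limit. The steps are an at least 1.1-fold lower number from compound 3 to compound 4 (0.05 log units; that floor lies within the scatter), an at least 1.1-fold lower number from compound 2 to compound 4 (0.05 log units; that floor lies within the scatter) and an at least 1.1-fold lower number from compound 1 to compound 4 (0.05 log units; that floor lies within the scatter). Each is only a floor, and the steps among compound 1, compound 2 and compound 3 cannot be read, so how far the thiazole change reaches stays unsized: the limit of > 2 h in this assay, at which 3 of the 4 values shown sit.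

The compounds shown leave open how a pyridine ring on the same ethoxy chain would read. They also leave open whether the methyl group on the thiazole ring bears on the half-life.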